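Aryl for Cyclohexyl on the Amide Nitrogen

A few compounds are considered here, and "the series" means these few. Any claim that something is new, unique, unknown or untested is made for them only; others in the source may bear on it.

Compound 3 `CCOC(=O)C1=Cc2ccccc2OC1(OCc1cn(CC(=O)NC2CCCCC2)nn1)C(F)(F)F` gives 9900 nM in a functional assay on A549 cells (Homo sapiens) for inhibition, read by MTT assay, with a stated time of 24 h (on this read-out lower numbers stand for stronger inhibition and higher numbers for weaker inhibition), and stands second highest of the three numbers measured, though every step to its neighbours is within the scatter. Compound 2 `CCOC(=O)C1=Cc2ccccc2OC1(OCc1cn(CC(=O)Nc2cccc(Cl)c2)nn1)C(F)(F)F` gives 12800 nM and compound 1 `CCOC(=O)C1=Cc2ccccc2OC1(OCc1cn(-c2ccc(F)cc2)nn1)C(F)(F)F` gives 7300 nM; the steps of a 1.3-fold lower number from compound 2 to compound 3 (0.11 log units; within the scatter) and a 1.4-fold higher number from compound 1 to compound 3 (0.13 log units; within the scatter) are both within the scatter. Compound 4 `CCOC(=O)C1=Cc2ccccc2OC1(OCc1cn(CC(=O)Nc2ccc(C)cc2)nn1)C(F)(F)F` differs from compound 3 by 4-methylphenyl in place of cyclohexyl on an amide-type nitrogen. Among the measured compounds shown here, the one measured step at this position, a 1.3-fold lower number from compound 2 to compound 3 (0.11 log units; within the scatter), shows that an aromatic ring and a saturated ring on this nitrogen gave numbers within the scatter of each other. No step beyond the scatter is therefore expected for a 1.1-fold higher number from compound 3 to compound 4 (0.05 log units; within the scatter). Compound 4 is estimated at 11000 nM, with a range of 5000 nM to 25000 nM.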

Compound 4, half-maximal inhibitory concentration: 54300 nM
Beside the measured number, compound 4's estimate is 4.9-fold (0.69 log units) below it, and the stated range ends below it.
By their numbers in this assay, from the lowest: compounds 1, 3 and 2 (each within the scatter of the next); then compound 4.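

In this assay this amide-type nitrogen proves sensitive to which ring it carries: a 5.5-fold higher number from compound 3 to compound 4 (0.74 log units; beyond the scatter) and a 4.2-fold higher number from compound 2 to compound 4 (0.63 log units; beyond the scatter) both lie beyond the scatter, so 4-methylphenyl parts from both cyclohexyl and 3-chlorophenyl, which had stayed within it. With ((4-methylphenyl)carbamoyl)methyl in place of 4-fluorophenyl on the aromatic nitrogen, a 7.4-fold higher number from compound 1 to compound 4 (0.87 log units; beyond the scatter) also lies beyond it. Nothing measured here explains this difference. As far as these compounds go, how phenyl, 3-methylphenyl or 4-aminophenyl on this nitrogen would read remains open, so the methyl group and its place on the ring cannot yet be told apart.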